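A few compounds are considered here, and "the series" means these few. Any claim that something is new, unique, unknown or untested is made for them only; others in the source may bear on it.

In a functional assay (Cortical neurone cells, Mus musculus, strain ICR), read by LDH release, with a stated time of 24 h (on this read-out higher numbers stand for an effect only at larger amounts of compound and lower numbers for an effect already at smaller amounts), compound 1 (`C=CCNC(=O)c1ccc(/C=C/c2ccc(O)c(O)c2)cc1`) gives 29.6 uM and compound 2 (`O=C(NCc1ccco1)c1ccc(/C=C/c2ccc(O)c(O)c2)cc1`) gives 58.3 uM. Going by the values given here, these two values lie within the scatter of each other, so compound 1 is not separated from the only other measured compound. Compound 3 (`O=C/C=C/c1ccc(/C=C/c2ccc(O)c(O)c2)cc1`) has not yet been measured in this assay. Its difference from compound 1 is 2-formylethenyl in place of allylcarbamoyl on an aromatic carbon. Among the compounds with values here, the sole measured step, a 2.0-fold higher number from compound 1 to compound 2 (0.29 log units; within the scatter), lies within the scatter. That step keeps the amide and alters only the group on its nitrogen, so it bears only loosely on this larger change. Within the data shown here, no measured compound lacks the amide, so the range must stay wide. No shift beyond the scatter is expected, and no direction is favoured. The estimated step is a 1.2-fold lower number from compound 1 to compound 3 (0.07 log units; within the scatter). The expected value for compound 3 is 25 uM, with an estimated range of 8 uM to 75 uM.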

Compound 3, concentration for half-maximal effect: 42.3 uM
Beside the measured number, compound 3's estimate is 1.7-fold (0.23 log units) below it; the range from low to high includes it.
By their numbers in this assay, from the lowest: compounds 1, 3 and 2 (each within the scatter of the next).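

In this assay, 2-formylethenyl in place of allylcarbamoyl on the aromatic carbon gives a 1.4-fold higher number from compound 1 to compound 3 (0.16 log units; within the scatter) and so does not separate the two compounds. Going by these compounds alone, this is the first step that removes the amide rather than changing the group on its nitrogen, and it shows that, in the core of compound 1, a value in this range does not depend on the amide or the amide hydrogen at this position. No supporting data bear on this result.

Going by these compounds, whether a carboxylic acid or an amine at this aromatic carbon would move the number beyond the scatter remains open. Also open, on these data alone, is whether the aldehyde carbonyl of 2-formylethenyl contributes at all, a question that a plain saturated alkyl chain in the same place would address.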